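The source may hold more compounds than are shown below. What is called first, only, known or untested is meant among the compounds shown, and "the series" means these compounds.

Going by the values given here, in an assay on HEK293 cells for inhibition of Voltage-dependent T-type calcium channel subunit alpha-1G (Homo sapiens), read by fluorescence, tested at 10 uM (a higher number here means more inhibition at the concentration tested (going by the name of the read-out), a lower number less inhibition), compound 2 `CCCc1nc(-c2ccccc2)c(CNCCN2CCN(c3cccc(F)c3)CC2)o1` gives 62.3%, the higher of the two numbers so far, while compound 1 `CCCc1nc(-c2ccccc2)c(CNCCN2CCN(c3cccc(C)c3)CC2)o1` gives 43.1%. Among the compounds with values here, the single measured step, a number 19.2 percentage points higher from compound 1 to compound 2 (beyond the scatter), is the only comparison at hand. Compound 3 `CCCc1nc(-c2ccccc2)c(CNCCN2CCN(c3cccc(C)c3C)CC2)o1` carries the change (2,3-dimethylphenyl in place of 3-fluorophenyl on an amine nitrogen in a ring). Within the data shown here, this runs the measured step partly backwards, since a methyl on the aromatic carbon returns in place of the fluoro, whereas the second methyl has no counterpart among the measured compounds. The step from compound 1 to compound 2 therefore bears on it directly: reversing it points to a decrease of roughly the same size, with the added methyl unaccounted for, so the range must stay wide. For compound 3 a value in the region of compound 1 at 43.1% is expected. Compound 3 is estimated at 42% (range 22% to 62%), an expected step of a number 20.3 percentage points lower from compound 2 to compound 3 (beyond the scatter).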

Compound 3, a percentage reported as inhibition, at one concentration (the size of the read-out at that concentration, not a potency): 66.7%
The estimate for compound 3 lay 24.7 percentage points below the measured number; measured number outside the range, above it.
By their numbers in this assay, from the lowest: compound 1; then compounds 2 and 3 (each within the scatter of the next).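

In this assay, methyl in place of hydrogen on an aromatic carbon gives a number 23.6 percentage points higher from compound 1 to compound 3 (beyond the scatter), so the aromatic ring on the ring amine nitrogen accepts a further methyl without loss, and a single added methyl is enough to change the read-out beyond the scatter. Fluoro is therefore not the only route to the higher read-out: for 2,3-dimethylphenyl in place of 3-fluorophenyl the result is a number 4.4 percentage points higher from compound 2 to compound 3 (within the scatter), and the two groups cannot be told apart here. No measurement available here explains the effect of the added methyl.

Still open, from the compounds shown here alone, is whether the read-out holds with 2,3-dichlorophenyl or with a methoxy group on this ring. The single-concentration percentages also leave open how these compounds rank in potency, and whether the propyl chain on the shared core could be replaced by a cyclopropyl group.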